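Dropping the trifluoromethyl from a T-type channel analogue

A few compounds are considered here, and "the series" means these few. Any claim that something is new, unique, unknown or untested is made for them only; others in the source may bear on it.

Three analogues sharing one core have been tested in an assay on HEK293 cells for inhibition of Voltage-dependent T-type calcium channel subunit alpha-1G (Homo sapiens), read by fluorescence, tested at 10 uM; on this read-out higher numbers stand for more inhibition at the one concentration tested (going by the name of the read-out) and lower numbers for less inhibition. Compound 1 `CCCc1nc(-c2ccccc2)c(CNCCN2CCN(c3cccc(C(F)(F)F)c3)CC2)o1` gives 56.3%, and compound 2 `CCCc1nc(-c2ccccc2)c(CNCCCN2CCN(c3cccc(C(F)(F)F)c3)CC2)o1` gives 51.6%, the two numbers falling within the usual scatter of each other. Compound 3 `Cc1nc(-c2ccccc2)c(CNCCCN2CCN(c3ccc(Cl)cc3)CC2)o1` gives 38.1%, a number beyond the scatter from that of compound 2. Compound 2 therefore stands in the upper pair of the three.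

The step from compound 2 to compound 4 `CCCc1nc(-c2ccccc2)c(CNCCCN2CCN(c3ccccc3)CC2)o1` replaces one group on the aryl ring: hydrogen in place of trifluoromethyl on an aromatic carbon. Among the measured compounds shown here, no measured pair shows this exact change, so only a moderate drop toward the region of compound 3 is expected, as reflected in a number 10.6 percentage points lower from compound 2 to compound 4 (beyond the scatter). Compound 4 is accordingly estimated to reach 41% in this assay , with a range from 26% to 57%.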

Compound 4, a percentage reported as inhibition, at one concentration (the size of the read-out at that concentration, not a potency): 43.7%
Estimate against measurement, compound 4: 2.7 percentage points below; the measured number falls inside the stated range.
By their numbers in this assay, from the lowest: compounds 3, 4, 2 and 1 (each within the scatter of the next, the first and the last beyond it).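

In this assay, the change from 3-(trifluoromethyl)phenyl to phenyl gives a number 7.9 percentage points lower from compound 2 to compound 4 (within the scatter). Among the compounds shown here, this is the first pair differing in one place, and it shows that the trifluoromethyl on this aromatic carbon is not needed for a reading within the scatter of compound 2. No evidence on the reason is at hand.

On these data alone, whether a nitrile or a methoxy group at this position would read alike stays open, as does whether the same change would give a similar step on the chain of compound 1.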